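Ethylamino for Cyclopropyl: Expected Cytotoxicity of Compound 3

A few compounds are considered here, and "the series" means these few. Any claim that something is new, unique, unknown or untested is made for them only; others in the source may bear on it.

Compound 1 `O=c1cc(-c2ccccc2)nc(-n2cccn2)[nH]1`: > 50000 nM
Compound 2 `Cc1cc(C2CC2)n(-c2nc(C(F)(F)F)cc(=O)[nH]2)n1`: 78000 nM

Of the compounds shown here, two have so far been measured in an ADME assay on CHO cells (Cricetulus griseus) for cytotoxicity, read by MTT assay; a higher number here means a weaker inhibitor, a lower number a stronger inhibitor. Compound 1 reaches only > 50000 nM there, which is a limit of the assay rather than a number. Going by the values given here, compound 2 gives 78000 nM in this assay and is the only compound with a plain number. The other value, that of compound 1, is the limit of > 50000 nM in this assay, at which 1 of the 2 values shown sits.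

Compound 3 `CCNc1cc(C)nn1-c1nc(C(F)(F)F)cc(=O)[nH]1` has not yet been measured in this assay. It differs from compound 2 in a single place: ethylamino in place of cyclopropyl on an aromatic carbon, in words ethylamino in place of cyclopropyl on an aromatic carbon. Among the compounds with values here, no step between two measured compounds is available to gauge such an exchange, and with compound 2 sitting at 78000 nM as the only plain number, there is no basis for expecting a shift beyond the usual scatter in either direction. Compound 3 is therefore estimated at 70000 nM, expected to fall between 30000 nM and 160000 nM. The implied step a 1.1-fold lower number from compound 2 to compound 3 (0.05 log units; within the scatter) is expected to stay within the scatter.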

Compound 3, half-maximal inhibitory concentration: 8000 nM
Compound 3: middle estimate off by 8.8-fold (0.94 log units), on the high side; the measured number lies below the stated range.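

Going by these compounds alone, compound 3 gives the first reading of this position, on an aromatic carbon next to the ring nitrogen: in this assay, ethylamino in place of cyclopropyl gives a 9.8-fold lower number from compound 2 to compound 3 (0.99 log units; beyond the scatter). The position therefore responds to the group it carries, and compound 3 is the stronger inhibitor of this pair, even though the leaving and entering groups have the same number of heavy atoms. Nothing measured here accounts for the step, and the one limit on record has no bearing on it.

The exchange changes several things at once: the three-membered ring is lost, a nitrogen joins the position, and a hydrogen-bond donor and acceptor are added, so this single step leaves open which of these changes matters. From the compounds shown here alone, a propyl chain, a cyclopropylamino group or a dimethylamino group at the same place would begin to separate these features, and it also remains open whether the lower number in this cytotoxicity read-out would hold with other groups on the rest of the shared core.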